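The source may hold more compounds than are shown below. What is called first, only, known or untested is meant among the compounds shown, and "the series" means these compounds.

Compound 1 `CCCSc1nc(N/N=C(\C)c2ccccc2O)c2nnn(Cc3ccco3)c2n1`: 5760 nM
Compound 2 `CCCSc1nc(N/N=C/c2cc(OC)c(OC)c(OC)c2)c2nnn(Cc3ccccc3)c2n1`: 4060 nM
Compound 3 `CCCSc1nc(N/N=C/c2ccc(Cl)cc2)c2nnn(Cc3ccccc3)c2n1`: > 64000 nM

All three compounds share one core and were tested in a functional assay on ECa-109 cells (Homo sapiens) for antiproliferative activity, read by MTT assay, with a stated time of 72 h; a higher number here means a weaker inhibitor, a lower number a stronger inhibitor. Compound 1 gives 5760 nM in this assay, one of only two results that came back as a number. The other number belongs to compound 2, which gives 4060 nM in this assay, and the gap between compound 1 and compound 2 lies within the scatter of repeated measurements, so no order can be set between them. For compound 3 the result in this assay is a limit, > 64000 nM, and not a number. That result is the limit of > 64000 nM in this assay, at which 1 of the 3 values shown sits.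

The unmeasured compound 4 `CCCSc1nc(N/N=C(\C)c2ccccc2O)c2nnn(Cc3cccc(Cl)c3)c2n1` differs from compound 1 in a single place: 3-chlorophenyl in place of furan-2-yl on a saturated chain carbon bound to an aromatic nitrogen. Among the measured compounds there is no pair that differs in this way alone, so the numbers give no direction for this step. The step in this assay is therefore estimated as a 1.0-fold lower number from compound 1 to compound 4 (0.02 log units; within the scatter), which amounts to no change beyond the scatter. On that basis compound 4 is expected to give about 5500 nM in this assay, with a range from 2000 nM to 16000 nM.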

Compound 4, half-maximal inhibitory concentration: 13000 nM
Beside the measured number, compound 4's estimate is 2.4-fold (0.37 log units) below it; the measured number falls inside the stated range.
By their numbers in this assay, from the lowest: compounds 2 and 1 (each within the scatter of the next); then compound 4. At a limit, above all of these: compound 3.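

In this assay, among the compounds shown here, the change at this position gives a 2.3-fold higher number from compound 1 to compound 4 (0.35 log units; beyond the scatter), the first step between measured compounds that differ in one place. It shows that the group on this saturated chain carbon bound to an aromatic nitrogen affects the read-out, though only modestly, since compound 4 still returns a number, 13000 nM, and not a limit. Nothing measured here bears on what lies behind this step.

The compounds shown leave open whether the step follows from the change of ring or from the chlorine, which a thiophen-2-yl or an unsubstituted phenyl on the same carbon, with the rest of compound 1 kept, could help to separate. They also leave open how a pyridin-3-yl or a morpholine-bearing group would read at this position, and whether the same change gives a step of similar size when the rest of the molecule is that of compound 2.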